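Extending the butyl chain of compound 3 with a cyclopentyl ring

The source may hold more compounds than are shown below. What is called first, only, known or untested is meant among the compounds shown, and "the series" means these compounds.

Compound 3 `CCCCc1nc2c(-c3ccc(Cl)cc3)n[nH]c2c(=O)n1NC(=O)c1ccccc1` gives 29100 nM in a functional assay on DU-145 cells (Homo sapiens) for inhibition, read by MTT assay, with a stated time of 2 days; a higher number here means a weaker inhibitor of growth, a lower number a stronger inhibitor of growth; it sits between compound 1 `COc1cccc(-c2nc3c(-c4ccc(Cl)cc4)n[nH]c3c(=O)n2NC(=O)c2ccccc2)c1`, which gives 17900 nM, and compound 2 `COc1cccc(Cc2nc3c(-c4ccc(Cl)cc4)n[nH]c3c(=O)n2NC(=O)c2ccccc2)c1`, which gives 44900 nM, and both of its steps, a 1.6-fold higher number from compound 1 to compound 3 (0.21 log units; within the scatter) and a 1.5-fold lower number from compound 2 to compound 3 (0.19 log units; within the scatter), stay within the scatter, so no order among the three can be claimed. Compound 4 `O=C(Nn1c(CCC2CCCC2)nc2c(-c3ccc(Cl)cc3)n[nH]c2c1=O)c1ccccc1` differs from compound 3 by cyclopentyl in place of ethyl on a saturated chain carbon, two bonds along the chain from an aromatic carbon. Among the measured compounds shown here, no measured step alters this chain in the same way; the steps at the same position, a 2.5-fold higher number from compound 1 to compound 2 (0.40 log units; beyond the scatter) and a 1.6-fold higher number from compound 1 to compound 3 (0.21 log units; within the scatter), show only small to modest movement as aryl, benzyl and butyl groups exchange. The step of a 1.2-fold lower number from compound 3 to compound 4 (0.07 log units; within the scatter) is therefore expected to be small, with no clear direction. Compound 4 is estimated at 25000 nM, with a range from 10000 nM to 60000 nM.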

Compound 4, concentration for 50% growth inhibition: 10200 nM
Compound 4: the middle estimate sits 2.5-fold (0.39 log units) above what was measured; low and high end bracket the measured number.
By their numbers in this assay, from the lowest: compounds 4, 1, 3 and 2 (each within the scatter of the next, the first and the last beyond it).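

Closing the end of the butyl chain into a cyclopentyl ring gives the first drop beyond the scatter at this position in this assay (a 2.9-fold lower number from compound 3 to compound 4 (0.46 log units; beyond the scatter)). The 2-cyclopentylethyl group also separates from the 3-methoxybenzyl group (a 4.4-fold lower number from compound 2 to compound 4 (0.64 log units; beyond the scatter)), but not from the 3-methoxyphenyl group (a 1.8-fold lower number from compound 1 to compound 4 (0.24 log units; within the scatter)). Nothing available explains these steps. On these data alone, it remains open whether the ring itself matters or only the added carbons, which a longer open chain would test. As far as these compounds go, a cyclohexyl ring, or an amine such as pyrrolidine at the chain end, also remains untested here.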